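The source may hold more compounds than are shown below. What is called first, only, known or untested is meant among the compounds shown, and "the series" means these compounds.

Going by the values given here, in a functional assay on RPMI-8226 cells (Homo sapiens) for inhibition, read by sulforhodamine B assay, with a stated time of 48 h, tested at 10 uM (a higher number here means more inhibition at the concentration tested (going by the name of the read-out), a lower number less inhibition), compound 1 `COc1ccc(-c2cn3ccnc3c(-c3ccc4ncn(C5CCCCC5)c4c3)n2)cc1` gives 95.6%, while compound 2 `c1ccc2c(-c3cn4ccnc4c(-c4ccc5ncn(C6CCCCC6)c5c4)n3)cccc2c1` gives 22.9%, the lower of the two numbers known here; the one measured step, a number 72.7 percentage points lower from compound 1 to compound 2 (beyond the scatter), is the only guide to how this position responds. Compound 3 `c1cn2cc(-c3ccsc3)nc(-c3ccc4ncn(C5CCCCC5)c4c3)c2n1` is the next member: thiophen-3-yl in place of naphthalen-1-yl on an aromatic carbon. The step from compound 1 to compound 2 shows that the large two-ring group at this position cost most of the inhibition, so removing it in favour of a single small ring is expected to move the number back upward, although whether a thiophen-3-yl behaves like the 4-methoxyphenyl of compound 1 is not shown by any measured pair. The step of a number 42.1 percentage points higher from compound 2 to compound 3 (beyond the scatter) is therefore estimated as a substantial rise, with wide uncertainty. Compound 3 is expected to give about 65% in this assay, within 20% to 95%.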

Compound 3, a percentage reported as inhibition, at one concentration (the size of the read-out at that concentration, not a potency): 37.9%
Beside the measured number, compound 3's estimate is 27.1 percentage points above it, within the range that was stated.
By their numbers in this assay, from the lowest: compound 2; then compound 3; then compound 1.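

In this assay, the change from naphthalen-1-yl to thiophen-3-yl gives only a modest recovery, a number 15 percentage points higher from compound 2 to compound 3 (beyond the scatter), while the change from 4-methoxyphenyl to thiophen-3-yl remains a large loss, a number 57.7 percentage points lower from compound 1 to compound 3 (beyond the scatter). Replacing the two-ring group with a single aromatic ring is therefore not enough by itself to restore the high inhibition seen with compound 1, so the response at this position depends on more than the removal of naphthalen-1-yl. Nothing available here explains why 4-methoxyphenyl stands so far above the other two groups.

On these data alone, it remains open whether the high inhibition depends on the methoxy group or on the phenyl ring that carries it. A plain phenyl group, or a phenyl group bearing an amine or a longer ether chain instead, would help to separate these possibilities.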